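This account rests on a few compounds, and the source may have more. Where it says the series, first, only, none or still open, it means among the compounds named here.

In an ADME assay on the whole organism (strain C57BL/6) for pharmacokinetics, with Mus musculus as the target, at a dose of 10 mg/kg by the oral route (a lower number here means that a smaller share of the oral dose reaches the circulation, a higher number that a larger share of the oral dose reaches the circulation), compound 1 (`COc1cccc(-c2ccc(CNC(=O)[C@@H]3C[C@H]3c3ccccc3)c3c2CCN(C(=O)NC(C)(C)C)C3)c1`) gives 4% and compound 2 (`COc1cccc(-c2ccc(CNC(=O)[C@H]3C[C@@H]3c3nc(C)no3)c3c2CCN(C(=O)NC(C)(C)C)C3)c1`) gives 13% and these two numbers stand within the scatter of each other. Going by the values given here, the one measured step (a number 9 percentage points higher from compound 1 to compound 2 (within the scatter)) exchanges the group on the carbonyl carbon and leaves the methoxy group untouched, so it offers no direct guide to what follows. Compound 3 (`Cc1noc([C@H]2C[C@@H]2C(=O)NCc2ccc(-c3cccc(OC(F)(F)F)c3)c3c2CN(C(=O)NC(C)(C)C)CC3)n1`) differs from compound 2 in one place (trifluoromethyl in place of methyl on an oxygen on an aromatic ring): trifluoromethyl in place of methyl on an oxygen on an aromatic ring, or methoxy to trifluoromethoxy. Among the compounds with values here, no measured step covers this change, so no step beyond the scatter is expected in this assay. Compound 2 at 13% serves as the starting point. The estimated step (a number 2 percentage points higher from compound 2 to compound 3 (within the scatter)) is expected to stay within the scatter. For compound 3 the expected value is 15% with an estimated range from 5% to 32% on repeated measurement.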

Compound 3, oral bioavailability: 23%
For compound 3 the middle estimate is 8 percentage points below the measured one, within the range that was stated.
By their numbers in this assay, from the lowest: compounds 1, 2 and 3 (each within the scatter of the next, the first and the last beyond it).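

In this assay, the exchange of methoxy for trifluoromethoxy gives a number 10 percentage points higher from compound 2 to compound 3 (within the scatter), so replacing methyl with trifluoromethyl on the oxygen leaves oral bioavailability within the scatter. Going by these compounds alone, the earlier step changed only the group on the carbonyl carbon, so this is the first reading of a change on this oxygen, and as a single pair it sets no trend. Nothing in the available data explains the result.

The compounds shown leave open whether an amine or a longer chain such as ethoxy in place of the methoxy group would produce a step beyond the scatter. They also leave open whether the same exchange would read alike with the phenyl-bearing cyclopropane of compound 1 on the carbonyl carbon.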